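Working notes: ethoxy in place of fluoro

The source may hold more compounds than are shown below. What is called first, only, known or untested is meant among the compounds shown, and "the series" means these compounds.

Measured so far in a functional assay on HepG2 cells (Homo sapiens) for antiproliferative activity, read by MTT assay, with a stated time of 48 h; on this read-out lower numbers stand for stronger inhibition and higher numbers for weaker inhibition
- compound 1 `COc1ccc(/C=C/c2cc(OC)cc(OC)c2/C=C/C(=O)c2ccc(C)cc2)cc1` gives 4.8 ug/mL
- compound 2 `COc1ccc(/C=C/c2cc(OC)cc(OC)c2/C=C/C(=O)c2ccc(F)cc2)cc1` gives 12.2 ug/mL

Compound 2 stands highest of the two numbers (12.2 ug/mL). Compound 3 `CCOc1ccc(C(=O)/C=C/c2c(/C=C/c3ccc(OC)cc3)cc(OC)cc2OC)cc1` carries ethoxy in place of fluoro on an aromatic carbon, para to a large group (ethoxy in place of fluoro on an aromatic carbon). For the measured compounds named here, the one measured step at this place is methyl to fluoro (a 2.5-fold higher number from compound 1 to compound 2 (0.41 log units; beyond the scatter)), modest and beyond the scatter. Ethoxy itself has no measured precedent here, so only a modest move to a lower number is expected in this assay (a 1.6-fold lower number from compound 2 to compound 3 (0.21 log units; within the scatter)). The estimated value for compound 3 is 7.5 ug/mL (expected range 3 ug/mL to 18 ug/mL).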

Compound 3, half-maximal inhibitory concentration: 8 ug/mL
For compound 3 the middle estimate is 1.1-fold (0.03 log units) below the measured one; measured number inside the range.
By their numbers in this assay, from the lowest: compounds 1, 3 and 2 (each within the scatter of the next, the first and the last beyond it).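

In this assay, ethoxy on an aromatic carbon, para to a large group, gives a 1.5-fold lower number from compound 2 to compound 3 (0.18 log units; within the scatter) and a 1.7-fold higher number from compound 1 to compound 3 (0.22 log units; within the scatter). Compound 3 therefore lies within the scatter of both neighbours, even though the earlier pair differ beyond it with a 2.5-fold higher number from compound 1 to compound 2 (0.41 log units; beyond the scatter), so three heavy atoms at this place still leave the number in the range set by methyl and fluoro. Nothing at hand bears on the reason for these steps. On these data alone, whether an amine, a carboxylic acid or a longer chain such as butoxy would leave that range stays open.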